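The source may report more compounds than this note shows. Statements on the series, on what has been measured and on what is new or still open speak of the compounds shown alone.

Values in a functional assay on HeLa cells (Homo sapiens) for inhibition, read by MTT assay, with a stated time of 72 h; a higher number here means a weaker inhibitor, a lower number a stronger inhibitor:
- Compound 1 `CC(=O)Oc1cc(C(=O)C2=C(O)[C@]3(CC=C(C)C)C[C@@H](C/C=C(\C)CCC=C(C)C)[C@](C)(CCC=C(C)C)[C@](CC=C(C)C)(C2=O)C3=O)ccc1O`: 8970 nM
- Compound 2 `CC(=O)Oc1ccc(C(=O)C2=C(O)[C@]3(CC=C(C)C)C[C@@H](C/C=C(\C)CCC=C(C)C)[C@](C)(CCC=C(C)C)[C@](CC=C(C)C)(C2=O)C3=O)cc1OC(C)=O`: 13400 nM

Within the data shown here, compound 1 sits within the scatter of compound 2, its only neighbour on these numbers, so the two cannot be ranked.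

Compound 3 `CC(C)=CCC/C(C)=C/C[C@@H]1C[C@]2(CC=C(C)C)C(=O)[C@@](CC=C(C)C)(C(=O)C(C(=O)c3ccc(O)c(OC(=O)CCCC[C@@H]4SCC5NC(=O)NC54)c3)=C2O)[C@@]1(C)CCC=C(C)C` keeps the core of compound 1 and carries one change: a group of 12 heavy atoms (8 carbon, 2 nitrogen, 1 oxygen, 1 sulfur; one five-membered non-aromatic ring with 1 hetero atom, one five-membered non-aromatic ring with 2 hetero atoms) in place of a hydrogen atom, on a saturated chain carbon bound to a carbonyl carbon.

Among the measured compounds shown here, the only measured step, a 1.5-fold higher number from compound 1 to compound 2 (0.17 log units; within the scatter), is acetyl in place of hydrogen on an oxygen on an aromatic ring. That step is small, so no step beyond the scatter is expected in this assay. For the measured compounds named here, it is weak guidance, though, since it lies at another place and no measured compound carries a group of this kind.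

The expected step is a 1.2-fold higher number from compound 1 to compound 3 (0.09 log units; within the scatter).

For compound 3 the estimate is 11000 nM, with an expected range of 4000 nM to 30000 nM.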

Compound 3, half-maximal inhibitory concentration: 12700 nM
Compound 3: the middle estimate sits 1.2-fold (0.06 log units) below what was measured, and the stated range covers the measured number.
By their numbers in this assay, from the lowest: compounds 1, 3 and 2 (each within the scatter of the next).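

At the saturated chain carbon bound to a carbonyl carbon, this assay gives a 1.4-fold higher number from compound 1 to compound 3 (0.15 log units; within the scatter) for a group of 12 heavy atoms in place of a hydrogen atom. Among these compounds, this is the first reading at this position, and even a group with one five-membered non-aromatic ring with 1 hetero atom and one five-membered non-aromatic ring with 2 hetero atoms, carrying 2 hydrogen-bond donors and 2 hydrogen-bond acceptors, produces no step beyond the scatter. No measurement offers an explanation for this result and a single group cannot establish a trend for the position.

On these data alone, whether an amine, a carboxylic acid or a simple longer alkyl chain on this carbon would shift the number remains open. The compounds shown also leave open whether any change here can produce a step beyond the scatter.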